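Trimming the Chloro Groups on a Phenyl Ring

The source may report more compounds than this note shows. Statements on the series, on what has been measured and on what is new or still open speak of the compounds shown alone.

Of the compounds shown here, three sharing one core have been tested in a functional assay on HL-60 cells (Homo sapiens) for antiproliferative activity, read by MTT assay, with a stated time of 72 h; a lower number here means a stronger inhibitor, a higher number a weaker inhibitor. Compound 1 `NC1=NC2(CCSCC2)N(OCCCOc2ccc(Cl)c(Cl)c2)C(N)=N1`, with a 3,4-dichlorophenyl group, gives 140 nM. Compound 2 `NC1=NC2(CCSCC2)N(OCCCOc2ccc(Br)cc2)C(N)=N1`, with a 4-bromophenyl group, gives 350 nM. Compound 3 `NC1=NC2(CCSCC2)N(OCCCOc2cc(Cl)c(Cl)cc2Cl)C(N)=N1`, with a 2,4,5-trichlorophenyl group, gives 730 nM, the highest number of the three and so the weakest result.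

Compound 4 `NC1=NC2(CCSCC2)N(OCCCOc2ccccc2Cl)C(N)=N1` has not been measured yet. It differs from compound 3 in one place, on an oxygen on a saturated carbon: 2-chlorophenyl in place of 2,4,5-trichlorophenyl on an oxygen on a saturated carbon.

Within the data shown here, two measured steps bear on this change, and both end at compound 3. Chloro in place of hydrogen on an aromatic carbon gave a 5.2-fold higher number from compound 1 to compound 3 (0.72 log units; beyond the scatter), while the other route gave a 2.1-fold higher number from compound 2 to compound 3 (0.32 log units; beyond the scatter). Both are modest but beyond the scatter, and read backwards, both show a lower number with fewer halogens on the ring. The trend is not simple, however: compound 2 carries fewer halogens than compound 1, yet the data show a 2.5-fold higher number from compound 1 to compound 2 (0.40 log units; beyond the scatter). Among the measured compounds shown here, no tested compound has the 2-chlorophenyl group, so only a modest move towards a lower number seems reasonable.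

The expected change in this assay is a 1.6-fold lower number from compound 3 to compound 4 (0.21 log units; within the scatter). Compound 4 is estimated at 450 nM, with an expected range from 150 nM to 1300 nM.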

Compound 4, half-maximal inhibitory concentration: 390 nM
Beside the measured number, compound 4's estimate is 1.2-fold (0.06 log units) above it; low and high end bracket the measured number.
By their numbers in this assay, from the lowest: compound 1; then compounds 2, 4 and 3 (each within the scatter of the next, the first and the last beyond it).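

In this assay, among these compounds, 2-chlorophenyl in place of 2,4,5-trichlorophenyl on an oxygen on a saturated carbon gives a 1.9-fold lower number from compound 3 to compound 4 (0.27 log units; within the scatter) and so does not clearly separate the two compounds, which means the drop seen in the earlier steps cannot be claimed for this change. The 2-chlorophenyl group also cannot be told apart from the 4-bromophenyl group, with a 1.1-fold higher number from compound 2 to compound 4 (0.05 log units; within the scatter) as the measured step in this assay and compounds 2, 3 and 4 forming a loose group by their neighbouring steps. Only the 3,4-dichlorophenyl group stands clear of 2-chlorophenyl, with a 2.8-fold higher number from compound 1 to compound 4 (0.44 log units; beyond the scatter) in the same assay, so the count of chlorine atoms alone does not order these compounds: compound 1 has more chlorine than compound 4 and the lower number, while compound 3 has the most chlorine and the highest number.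

Nothing available explains why the 3,4-dichlorophenyl group gives the lowest number of this set. Still open, as far as these compounds go, is how this position would respond to an unsubstituted phenyl ring, to a methoxy group or a carboxylic acid on the ring, or to a longer chain carrying the ring.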